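Dimethylamino for phenoxy: next measurement in the series

This account rests on a few compounds, and the source may have more. Where it says the series, first, only, none or still open, it means among the compounds named here.

Measured so far:
compound 1 `COc1cc(C)cc(-c2c(-c3ccnc(-c4ccc(C(C)=O)cc4)c3)cnn2CC#N)c1` — 95%
compound 2 `Cc1cc(O)cc(-c2nn(CC#N)cc2-c2ccnc(-c3ccc(Oc4ccccc4)cc3)c2)c1` — 103%

Both numbers come from a functional assay on EKVX cells (Homo sapiens) for cytotoxicity, read by sulforhodamine B assay, with a stated time of 48 h, tested at 0.001 uM; on this read-out higher numbers stand for a weaker effect at the one concentration tested and lower numbers for a stronger effect. In this assay compound 1 gives 95% and compound 2 gives 103%. Compound 2 stands at the top end of these two numbers, but the gap to compound 1 lies within the usual scatter, so no order between them can be read; both sit close to the level of no effect at the single concentration tested.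

Compound 3 `Cc1cc(O)cc(-c2nn(CC#N)cc2-c2ccnc(-c3ccc(N(C)C)cc3)c2)c1` is the next member to be measured. It differs from compound 2 in one place: dimethylamino in place of phenoxy on an aromatic carbon. Among the compounds with values here, no step between measured compounds is available for this change, so the expectation rests only on the two numbers above and on the change itself.

Compound 3 is expected near 98%, with a range from 85% to 110%. The expected step of a number 5 percentage points lower from compound 2 to compound 3 (within the scatter) is none beyond the scatter, since neither measured compound shows an effect at this concentration that the exchange would have to preserve or lose.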

Compound 3, a percentage reported as activity, at one concentration (the size of the read-out at that concentration, not a potency): 96%
Compound 3: middle estimate off by 2 percentage points, on the high side, within the range that was stated.
By their numbers in this assay, from the lowest: compounds 1, 3 and 2 (each within the scatter of the next).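

In this assay, dimethylamino in place of phenoxy on an aromatic carbon, para to a large group, gives a number 7 percentage points lower from compound 2 to compound 3 (within the scatter). Within the data shown here, this is the first pair that differs in one place, and it shows that replacing a group of 7 heavy atoms with a six-membered aromatic ring by one of 3 heavy atoms with no ring produces no difference that can be read at this single concentration, with the hydrogen-bond counts of the two groups the same. No measured property of either group is available to bear on this result.

The compounds shown leave open whether a carboxylic acid or a morpholine ring at this place would move the read-out beyond the scatter. They also leave open whether compound 2 and compound 3 would separate at a higher concentration, since one concentration gives the size of an effect and not a potency, and compound 1 differs from both in more than one place.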